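Swapping the Heterocycle on Sulfur: What Compound 4 Might Give

This account rests on a few compounds, and the source may have more. Where it says the series, first, only, none or still open, it means among the compounds named here.

Compound 1 `CC(C)[C@H](NC(=O)COc1cccc2ccccc12)C(=O)N[C@@H](CC(=O)O)C(=O)CSC1=NCCS1` gives in a functional assay on Jurkat cells (Homo sapiens) for inhibition (a lower number here means a stronger inhibitor, a higher number a weaker inhibitor), a value of > 200000 nM, which is a limit of the assay and not a number.
Compound 2 `CC(C)[C@H](NC(=O)COc1cccc2ccccc12)C(=O)N[C@@H](CC(=O)O)C(=O)CSc1nncn1C` gives in this assay a value of > 200000 nM, again a limit of the assay.
Compound 3 `CC(C)[C@H](NC(=O)COc1cccc2ccccc12)C(=O)N[C@@H](CC(=O)O)C(=O)CSc1nnnn1-c1ccccc1` gives in this assay a value of 153000 nM.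

Within the data shown here, compound 3 therefore holds the only actual number among the three; the other two values sit at the limit of > 200000 nM in this assay, at which 2 of the 3 values shown sit. The two measured steps that lead to compound 3, an at least 1.3-fold lower number from compound 1 to compound 3 (0.11 log units; that floor lies within the scatter) and an at least 1.3-fold lower number from compound 2 to compound 3 (0.11 log units; that floor lies within the scatter), each exchange only the heterocycle attached to the sulfur, and both have floors that lie within the scatter, so neither shows a shift that can be read beyond it.

Compound 4 `CC(C)[C@H](NC(=O)COc1cccc2ccccc12)C(=O)N[C@@H](CC(=O)O)C(=O)CSc1nc2ccccc2o1` differs from compound 3 by 1,3-benzoxazol-2-yl in place of 1-phenyl-1H-tetrazol-5-yl on a sulfur. This is once more an exchange of the heterocycle on the sulfur, the same kind of change as in the two measured steps, and those steps offered no readable shift. Compound 4 is therefore expected to stand close to where compound 3 stands in this assay, with a real chance that only a limit is reported. The expected step is a 1.2-fold higher number from compound 3 to compound 4 (0.07 log units; within the scatter). For compound 4 the estimated value is 180000 nM, with a range from 70000 nM to 400000 nM.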

Compound 4, half-maximal inhibitory concentration: > 200000 nM
Compound 4 gave a limit, no number; the forecaster's own chance of this, stated with the estimate: 45%; middle value at least 1.1-fold (0.04 log units) away from the limit.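

In this assay, exchanging 1-phenyl-1H-tetrazol-5-yl for 1,3-benzoxazol-2-yl on the sulfur gives an at least 1.3-fold higher number from compound 3 to compound 4 (0.11 log units; that floor lies within the scatter). Both groups hold one five-membered aromatic ring and one six-membered aromatic ring of carbon only, so this pair of rings is kept while the five-membered ring goes from 4 hetero atoms to 2, and that change brings no shift that can be read beyond the scatter. The steps to compound 4 from compound 1 and from compound 2 cannot be read, and the series now rests mostly on a single limit of the assay, with compound 3 alone giving a number: the limit of > 200000 nM in this assay, at which 3 of the 4 values shown sit.

Among these compounds, whether any group on this sulfur can move the value clearly beyond the scatter stays open, since the one number available lies within the scatter of the limit that the other compounds reach. Also open, on these data alone, is what a plain phenyl ring, with no hetero atoms, or a short chain such as ethyl would give on the same sulfur with the rest of the shared core unchanged.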